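The source may hold more compounds than are shown below. What is called first, only, known or untested is meant among the compounds shown, and "the series" means these compounds.

In an ADME assay on BJ cells (Homo sapiens) for cytotoxicity, read by luminescence, with a stated time of 72 h (a lower number here means that less compound is needed, a higher number that more compound is needed for the effect), compound 1 (`CCOC(=O)c1c(-c2cccc(-c3ccccc3)c2)[nH]c2cc(OC)c(F)cc2c1=O`) gives > 21500 nM, which is a limit and not a number. Compound 2 (`CCOC(=O)c1c(-c2cccc(OC)c2)[nH]c2cc(OC)c(F)cc2c1=O`) gives > 21500 nM, also a limit. Compound 3 (`CCOC(=O)c1c(-c2cccc(Oc3ccccc3)c2)[nH]c2cc(OC)c(F)cc2c1=O`) gives > 21500 nM, again a limit. Compound 3 therefore has no exact value and stands with the other two at the limit of > 21500 nM in this assay, at which 3 of the 3 values shown sit.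

Compound 4 (`COc1cc2[nH]c(-c3cccc(Oc4ccccc4)c3)c(C(=O)NCCN3CCCC3)c(=O)c2cc1F`) keeps the core and the phenoxy group of compound 3 but carries (2-(pyrrolidin-1-yl)ethyl)amino in place of ethoxy on a carbonyl carbon. The same difference can be read as ethoxycarbonyl giving way to (2-(pyrrolidin-1-yl)ethyl)carbamoyl.

The measured steps give little guidance. Methoxy in place of phenyl is a step that the two limits leave unreadable from compound 1 to compound 2, phenoxy in place of phenyl is a step that the two limits leave unreadable from compound 1 to compound 3, and phenyl in place of methyl on an oxygen is a step that the two limits leave unreadable from compound 2 to compound 3. None of these changes touches the carbonyl carbon, and none has a readable size, so the expectation for this assay is tentative. This new group is a larger change than any measured so far, so a modest move towards less compound being needed is expected, though another limit would be no surprise.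

The expected change is an at least 1.4-fold lower number from compound 3 to compound 4 (0.15 log units; that floor lies within the scatter). For compound 4 the estimated value is 15000 nM, within an expected range from 5000 nM to 30000 nM.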

Compound 4, half-maximal effective concentration: > 21500 nM
Compound 4: a limit, no number (the forecaster's own chance of this, stated with the estimate: 50%); at least 1.4-fold (0.15 log units) between middle value and limit.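

Compound 3 and compound 4 both end at a limit rather than a number, so the change from ethoxy to (2-(pyrrolidin-1-yl)ethyl)amino has no readable size: the limit of > 21500 nM in this assay, at which 4 of the 4 values shown sit.

The compounds shown leave open whether any of these changes moves the read-out at all, and at what concentration any of the four would reach the half-maximal effect.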